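This account rests on a few compounds, and the source may have more. Where it says the series, first, only, none or still open, it means among the compounds named here.

Three compounds have so far been measured in a functional assay on SK-MEL-28 cells (Homo sapiens) for inhibition, read by sulforhodamine B assay, with a stated time of 48 h; on this read-out lower numbers stand for stronger inhibition of growth and higher numbers for weaker inhibition of growth:

Compound 1 `Nc1cc(N)c2nc(-c3ccccc3)c(NCc3ccc(Cl)c(Cl)c3)nc2c1` gives 41700 nM.
Compound 2 `COc1ccc(CNc2nc3cc(N)cc(N)c3nc2-c2ccccc2)cc1OC` gives 30200 nM.
Compound 3 `CCOC(=O)[C@H](CCC(=O)O)NC(=O)c1ccc(Sc2nc3cc(N)cc(N)c3nc2-c2ccccc2)cc1` gives 33900 nM.

All three values lie within the usual scatter of one another, so compound 2 cannot be set apart from compound 1 or compound 3 on these numbers. Going by the values given here, the only single-point step among them, a 1.4-fold lower number from compound 1 to compound 2 (0.14 log units; within the scatter), shows that swapping the substituents on the benzylic ring of this series left the read-out essentially unchanged. Compound 3, which carries a quite different side chain, nevertheless lands close to compound 2.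

Compound 4 `COc1cc(CNc2nc3cc(N)cc(N)c3nc2-c2ccccc2)cc(OC)c1OC` is the next compound to be tested. It differs from compound 2 by methoxy in place of hydrogen on an aromatic carbon, the new group sitting on an aromatic carbon of a six-membered aromatic ring of carbon only, ortho to a methoxy group, meta to a large group and meta to a methoxy group. Among the compounds with values here, the one step that bears on this change is the exchange from compound 1 to compound 2, and it stayed within the scatter. Within the data shown here, with that as the only guide, no step beyond the scatter is expected. Compound 4 is therefore estimated to give about 30000 nM, within 12000 nM to 75000 nM. This estimate means a 1.0-fold lower number from compound 2 to compound 4 (0.00 log units; within the scatter), which is expected to remain within the scatter.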

Compound 4, concentration for total growth inhibition: 17800 nM
For compound 4 the middle estimate is 1.7-fold (0.23 log units) above the measured one; the range from low to high includes it.
By their numbers in this assay, from the lowest: compounds 4, 2, 3 and 1 (each within the scatter of the next, the first and the last beyond it).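

In this assay, putting methoxy in place of hydrogen on this aromatic carbon, ortho to a methoxy group and meta to a methoxy group, gives a 1.7-fold lower number from compound 2 to compound 4 (0.23 log units; within the scatter). The earlier step on this ring exchanged groups that were already there, whereas this one fills a ring carbon that carried only hydrogen, and it shows that this place accepts methoxy with no step beyond the scatter. No independent measurement bears on this result, so the data give no account of it.

The compounds shown leave open whether a different group at this same place, such as a hydroxyl, a fluorine or an amine, would also stay within the scatter of compound 2, and whether a longer chain such as ethoxy would do so. Going by these compounds alone, they also leave open whether methoxy at this place would give the same result on a ring without the other two methoxy groups, since every comparison here at this carbon rests on the single pair of compound 2 and compound 4.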